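This account rests on a few compounds, and the source may have more. Where it says the series, first, only, none or still open, it means among the compounds named here.

Series notes, urea set in an assay on isolated protein for inhibition of transient receptor potential cation channel subfamily V member 1 (Homo sapiens), read by calcium flux; a higher number here means a weaker inhibitor, a lower number a stronger inhibitor. For the measured compounds named here, compound 1 `O=C(Nc1cccc2[nH]ncc12)NC1CCc2c(C3CC3)cccc21` gives 5 nM and compound 2 `Cc1cccc2c1CCC2NC(=O)Nc1cccc2[nH]ncc12` gives 46 nM; the one single-point step so far, a 9.2-fold higher number from compound 1 to compound 2 (0.96 log units; beyond the scatter), is methyl in place of cyclopropyl on an aromatic carbon. Compound 3 `O=C(Nc1cccc2[nH]ncc12)NC1CCc2cc(Br)ccc21` gives 9 nM, which stands second highest of the three numbers recorded: its number and that of compound 1 sit within the scatter of each other, so no order between them is claimed, while its number is clearly lower than that of compound 2, beyond the scatter.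

Next in line is compound 4 `O=C(Nc1cccc2[nH]ncc12)NC1CCc2cc(Cl)ccc21`. The change from compound 3 is chloro in place of bromo on an aromatic carbon. Going by the values given here, no measured step bears on this exchange: the only step recorded concerns methyl against cyclopropyl at a different aromatic carbon, and nothing in the set tests one halogen against another. Among the compounds with values here, with no step to lean on, the expectation is a change no larger than the scatter, a 1.3-fold higher number from compound 3 to compound 4 (0.12 log units; within the scatter), in either direction. Compound 4 is therefore estimated at 12 nM, with a range of 5 nM to 30 nM.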

Compound 4, half-maximal inhibitory concentration: 10 nM
Compound 4: the middle estimate sits 1.2-fold (0.08 log units) above what was measured, and the stated range covers the measured number.
By their numbers in this assay, from the lowest: compounds 1, 3 and 4 (each within the scatter of the next); then compound 2.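

In this assay, chloro in place of bromo on an aromatic carbon, meta to a fused ring and para to a fused ring, gives a 1.1-fold higher number from compound 3 to compound 4 (0.05 log units; within the scatter), so the two halogens cannot be told apart at this position. For the compounds shown here, this is the only step in the set that exchanges one halogen for another, and it shows that this carbon carries either bromo or chloro with no readable change in the number, whereas the step at a different aromatic carbon, methyl in place of cyclopropyl, gave a 9.2-fold higher number from compound 1 to compound 2 (0.96 log units; beyond the scatter) and involved a different pair of groups, so it says nothing about halogens. Nothing measured on these compounds accounts for the two halogens reading alike.

Still open is how far this tolerance extends at the same carbon: the compounds shown do not tell whether fluoro, methoxy, an amine or a carboxylic acid there would stay within the scatter of bromo and chloro. Also open, going by these compounds, is whether bromo or chloro would read the same at the aromatic carbon that carries cyclopropyl in compound 1.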